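Hydroxy for dimethylamino on a benzimidazole-bearing series

This account rests on a few compounds, and the source may have more. Where it says the series, first, only, none or still open, it means among the compounds named here.

Of the compounds shown here, two carry numbers so far. Compound 1 `COc1cc(-c2nc3cc([N+](=O)[O-])ccc3[nH]2)ccc1O` was run in a functional assay on aorta (Rattus norvegicus, strain Wistar) for inhibition, with a stated time of 60 min (a higher number here means a larger maximal response, a lower number a smaller maximal response), and compound 1 reaches 91.7%. Compound 2 `CN(C)c1ccc(-c2nc3cc(C(F)(F)F)ccc3[nH]2)cc1` in this assay reaches 63.2%. Among the two numbers compound 2 stands lowest, and its nearest neighbour is compound 1, whose number lies higher by a margin beyond the scatter. The two compounds differ in more than one place, so no single change can be read from their gap.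

Compound 3 `Oc1ccc(-c2nc3cc(C(F)(F)F)ccc3[nH]2)cc1` is the next member to be measured in this assay. It differs from compound 2 by hydroxy in place of dimethylamino on an aromatic carbon. The remaining part of the structure, including the trifluoromethyl on the shared core, is kept.

Within the data shown here, no measured pair with this single change exists, so the expected size of the step rests on the one hydroxy-bearing compound in hand. Compound 1 carries a hydroxy and reaches 91.7%, though it also differs from compound 3 elsewhere. A moderate upward step from compound 2 to compound 3 is expected, a number 12.8 percentage points higher from compound 2 to compound 3 (beyond the scatter). For compound 3 the expected value in this assay is 76%, within a range from 58% to 94%.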

Compound 3, largest response reached (Emax), in percent of the reference or control that the assay uses: 51.2%
Beside the measured number, compound 3's estimate is 24.8 percentage points above it, outside the stated range (below it).
By their numbers in this assay, from the lowest: compound 3; then compound 2; then compound 1.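

In this assay, among these compounds, the one change read cleanly at this position, hydroxy in place of dimethylamino on an aromatic carbon para to a large group, gives a number 12 percentage points lower from compound 2 to compound 3 (beyond the scatter) with the trifluoromethyl on the shared core kept. Among the compounds shown here, this is the first evidence that the group on this carbon alone can shift the maximal response, and here the shift runs downward on going to hydroxy. For the compounds shown here, nothing measured so far explains why the step runs in this direction or has this size.

With a single pair at this position, the step cannot show whether the lower number follows the departure of dimethylamino or the arrival of hydroxy, and a primary amine, a methoxy or a carboxylic acid on the same carbon would help to separate those two readings. Going by these compounds, it is also open whether the same exchange gives a step of similar direction and size when another group, such as a nitrile, replaces the trifluoromethyl on the shared core.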